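Ring hydroxyl position and solubility across two cores

The source may hold more compounds than are shown below. What is called first, only, known or untested is meant among the compounds shown, and "the series" means these compounds.

The set comprises compound 1 `O=C(/C=C/c1cccc(O)c1)CC(=O)/C=C/c1cccc(O)c1O`, compound 2 `O=C(/C=C/c1ccc(O)cc1)CC(=O)/C=C/c1cccc(O)c1O`, compound 3 `O=C(/C=C/c1cccc(O)c1)/C=C/c1cccc(O)c1O` and the not yet measured compound 4 `O=C(/C=C/c1ccc(O)cc1)/C=C/c1cccc(O)c1O`. In a physicochemical assay for solubility, using the shake flask method, with a stated time of 12 h (a lower number here means a less soluble compound, a higher number a more soluble compound), compound 1 gives 8200 nM, compound 2 gives 4800 nM and compound 3 gives 184000 nM, the highest of the three and beyond the scatter from both others. The difference between the core of compound 1 and the core of compound 3 is not broken down here. Between compound 1 and compound 2 the change is 4-hydroxyphenyl in place of 3-hydroxyphenyl on a double-bonded chain carbon bound to a double-bonded chain carbon, which gave a 1.7-fold lower number from compound 1 to compound 2 (0.23 log units; within the scatter). The same change, (4-hydroxyphenyl in place of 3-hydroxyphenyl on a double-bonded chain carbon bound to a double-bonded chain carbon), turns compound 3 into compound 4. The expected step in this assay is a 1.5-fold lower number from compound 3 to compound 4 (0.19 log units; within the scatter), resting on a 1.7-fold lower number from compound 1 to compound 2 (0.23 log units; within the scatter). Compound 4 is therefore estimated at 120000 nM, between 50000 nM and 300000 nM.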

Compound 4, solubility: 120000 nM
Beside the measured number, compound 4's estimate shows no gap at the digits printed; the measured number falls inside the stated range.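

Working notes: in this assay, placing 4-hydroxyphenyl in place of 3-hydroxyphenyl on a double-bonded chain carbon bound to a double-bonded chain carbon gives (a 1.5-fold lower number from compound 3 to compound 4 (0.19 log units; within the scatter)) on one core and (a 1.7-fold lower number from compound 1 to compound 2 (0.23 log units; within the scatter)) on the other, so the change stays within the scatter on both cores. This shows that the swap carried over between these two cores without a step beyond the scatter, but it does not establish a real effect of the change or that it would carry to any further core. Nothing measured here accounts for these steps.

Still open, from the compounds shown here alone, is whether the same swap stays within the scatter on a third core. Also open, going by these compounds, is how an amine or a carboxylic acid in place of the ring hydroxyl would read in this assay on either core.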